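A Smaller Ether Group on an Inactive Compound

This account rests on a few compounds, and the source may have more. Where it says the series, first, only, none or still open, it means among the compounds named here.

Compound 1, `Cc1cc(C(=O)O)ccc1-c1noc(-c2ccc(C3CCCCC3)cc2)n1`: in a functional assay on CHO cells with sphingosine 1-phosphate receptor 4 (Homo sapiens) as the target, read by GTPgammaS binding (a lower number here means that less compound is needed, a higher number that more compound is needed for the effect), compound 1 gives > 10000 nM, which is a limit of the assay and not a number.
Compound 2, `Cc1cc(CCC(=O)O)ccc1-c1noc(-c2ccc(OC(C)C)c(C(F)(F)F)c2)n1`: in this assay compound 2 gives > 10000 nM, likewise a limit of the assay and not a number.

Neither measured compound reaches a measurable effect within the tested range. Compound 2 therefore stands not at a value but at the limit, the same limit at which the other reported value also sits, as the limit of > 10000 nM in this assay, at which 2 of the 2 values shown sit, records. Within the data shown here, with two limits and no numbers, no step between measured compounds can be read, and nothing shows how the tested range of structures moves the read-out.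

Compound 3 is `COc1ccc(-c2nc(-c3ccc(CCC(=O)O)cc3C)no2)cc1C(F)(F)F`. It differs from compound 2 by methyl in place of isopropyl on an oxygen on an aromatic ring. No measured change of this kind exists here, so the expectation rests only on compound 2 sitting at the limit. The step from compound 2 to compound 3 is expected to stay within the scatter, with no direction that can be told, and compound 3 is most likely to return only a limit again. The estimate for compound 3 in this assay is 15000 nM, within a range of 5000 nM to 50000 nM, with the expected step that the limit leaves unreadable from compound 2 to compound 3.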

Compound 3, half-maximal effective concentration: > 10000 nM
Compound 3: no number, only a limit (the forecaster's own chance of this, stated with the estimate: 85%); the middle value is on the limit's open side.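

In this assay compound 3 gives > 10000 nM as a limit and not a number. Among these compounds, compound 2 also stands at a limit, so the change from isopropoxy to methoxy between compound 2 and compound 3 gives no step that can be read. The compounds shown leave open which change in structure would bring a measurable value, for all of them stop at the same point: the limit of > 10000 nM in this assay, at which 3 of the 3 values shown sit.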